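Adding a Methyl Beside a Sulfur Chain: Tolerability Outlook

The source may report more compounds than this note shows. Statements on the series, on what has been measured and on what is new or still open speak of the compounds shown alone.

Compound 1 `CCC(c1nc(SC(C)C)[nH]c(=O)c1C)c1c(F)cccc1Cl` and compound 2 `CCC(C)Sc1nc(C(CC)c2c(F)cccc2Cl)c(C)c(=O)[nH]1` share one core and differ by methyl in place of hydrogen on a saturated chain carbon, two bonds along the chain from a sulfur. In an ADME assay on MT4 cells (Homo sapiens) for activation, read by MTT assay (a lower number here means that less compound is tolerated, a higher number that more compound is tolerated), compound 1 gives > 3000 nM, which is a limit of the assay and not a number. In this assay compound 2 gives > 3000 nM, likewise a limit. The step that the two limits leave unreadable from compound 1 to compound 2 therefore has no readable size, since both ends sit at the limit of > 3000 nM in this assay, at which 3 of the 3 values shown sit.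

Compound 3 `CCCSc1nc(C(C)c2c(F)cccc2F)c(CC)c(=O)[nH]1` is built on a different core; the difference between the two cores is not broken down here. In this assay compound 3 gives > 3000 nM, again a limit, and it is the third value sitting at the limit of > 3000 nM in this assay, at which 3 of the 3 values shown sit.

Compound 4 `CCc1c(C(C)c2c(F)cccc2F)nc(SC(C)CC)[nH]c1=O` has not yet been measured. It differs from compound 3 by methyl in place of hydrogen on a saturated chain carbon bound to a saturated chain carbon and a sulfur. For the measured compounds named here, this is the same kind of change as the one from compound 1 to compound 2, though the place is not identical: in the earlier pair the methyl entered on a saturated chain carbon two bonds along the chain from a sulfur, whereas here it enters on a saturated chain carbon bound to a saturated chain carbon and a sulfur.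

The step that the limit leaves unreadable from compound 3 to compound 4 is expected to be small, because compound 3 already sits at the limit of > 3000 nM in this assay, at which 3 of the 3 values shown sit, and the comparable step that the two limits leave unreadable from compound 1 to compound 2 stayed within the limit at both ends. Compound 4 is therefore estimated to give 4000 nM, within 1500 nM to 10000 nM, and most probably the assay will once more report only a limit.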

Compound 4, half-maximal cytotoxic concentration: > 3000 nM
Compound 4 was reported as a limit (the forecaster's own chance of this, stated with the estimate: 80%); the middle value lies beyond the limit too.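

In this assay compound 4 gives > 3000 nM as a limit of the assay and not a number. The step from compound 3 to compound 4 therefore cannot be read, because both ends sit at the same limit: (the limit of > 3000 nM in this assay, at which 4 of the 4 values shown sit). The compounds shown leave open how much of each compound the cells actually tolerate, and whether the added methyl changes that at all.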